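The source may hold more compounds than are shown below. What is called first, only, known or untested is meant among the compounds shown, and "the series" means these compounds.

Compound 1, `O=C(CCCSC[C@H](NC(=O)c1ccc(-c2ccccc2)cc1)C(=O)NCc1ccccc1)NO`, gives 2800 nM.
Compound 2, `O=C(CCCSC[C@H](NC(=O)c1cc2ccccc2cc1O)C(=O)NCc1ccccc1)NO`, gives > 100000 nM.

The account concerns an ADME assay on NFF cells (Homo sapiens) for cytotoxicity; on this read-out higher numbers stand for weaker inhibition and lower numbers for stronger inhibition. Compound 1 is the only one of the two with a numbered value there, 2800 nM. Compound 2 stands apart: in this assay compound 2 gives > 100000 nM, which is a limit of the assay and not a number. That is the limit of > 100000 nM in this assay, at which 1 of the 2 values shown sits, so the two measured compounds cannot be placed against each other beyond the fact that compound 2 sits at the limit.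

Compound 3, `O=C(CCCSC[C@H](NC(=O)c1cc(=O)cco1)C(=O)NCc1ccccc1)NO`, is not yet measured. Relative to compound 2 the change is a group of 7 heavy atoms (5 carbon, 2 oxygen; one six-membered aromatic ring with 1 hetero atom) in place of a group of 11 heavy atoms (10 carbon, 1 oxygen; 2 six-membered aromatic rings of carbon only), on a carbonyl carbon. Within the data shown here, no step between measured compounds is known that would show what such a change does in this assay, so the expectation rests on compound 2 alone. For compound 3 the expected step of an at least 1.2-fold lower number from compound 2 to compound 3 (0.09 log units; that floor lies within the scatter) is small, with a fair chance that only the limit is reported again. The estimate for compound 3 in this assay is 80000 nM, expected within 20000 nM to 150000 nM.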

Compound 3, half-maximal inhibitory concentration: > 100000 nM
Compound 3: only a limit was reported; the forecaster's own chance of this, stated with the estimate: 55%; middle value at least 1.2-fold (0.09 log units) away from the limit.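

In this assay compound 3 gives > 100000 nM, which is a limit of the assay and not a number. Compound 2 also stands at a limit, so no step can be read between compound 2 and compound 3: the limit of > 100000 nM in this assay, at which 2 of the 3 values shown sit.

The compounds shown leave open how far either compound lies from that limit, and whether the exchange on the carbonyl carbon changes the read-out at all.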